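Swapping a Cyclopropyl for a Butyl Group

The compounds below may be only part of what the source reports. "The series", "measured", "known", "first", "only" and "open" are said of these compounds alone.

Of the compounds shown here, three sharing one core have been tested in a functional assay on HepG2 cells (Homo sapiens) for antiproliferative activity, read by MTT assay, with a stated time of 72 h; on this read-out higher numbers stand for weaker inhibition and lower numbers for stronger inhibition. Compound 1 `O=C1O[C@H]([C@@H](O)Cn2cc(CNS(=O)(=O)c3ccc(Cl)cc3F)nn2)C(OCc2ccccc2)=C1OCc1ccccc1` gives 25500 nM. Compound 3 `O=C1O[C@H]([C@@H](O)Cn2cc(C3CC3)nn2)C(OCc2ccccc2)=C1OCc1ccccc1` gives 38100 nM, the higher of the two numbers shown, although its gap to compound 1 lies within the usual scatter. Compound 2 `COc1ccccc1-c1cn(C[C@H](O)[C@H]2OC(=O)C(OCc3ccccc3)=C2OCc2ccccc2)nn1` reaches only a limit of the assay, > 100000 nM, rather than a number. Going by the values given here, the single measured step in this set, an at least 2.6-fold lower number from compound 2 to compound 3 (0.41 log units; beyond the scatter), is the only evidence on how the group at this position moves the read-out.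

Compound 4 `CCCCc1cn(C[C@H](O)[C@H]2OC(=O)C(OCc3ccccc3)=C2OCc2ccccc2)nn1` is not yet measured; it differs from compound 3 by butyl in place of cyclopropyl on an aromatic carbon. Butyl, like the cyclopropyl it replaces, is built of carbon only, whereas the measured step exchanged a 2-methoxyphenyl for a cyclopropyl, so that step bears only loosely on this one. Among the compounds with values here, with no closer precedent, the expected step of a 1.0-fold higher number from compound 3 to compound 4 (0.02 log units; within the scatter) is none beyond the scatter. Compound 4 is therefore estimated at 40000 nM, with a likely range from 15000 nM to 100000 nM.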

Compound 4, half-maximal inhibitory concentration: 32800 nM
The estimate for compound 4 lay 1.2-fold (0.09 log units) above the measured number; the range from low to high includes it.
By their numbers in this assay, from the lowest: compounds 1, 4 and 3 (each within the scatter of the next). At a limit, above all of these: compound 2.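

In this assay, replacing the three-membered carbon ring with an open butyl chain gives a 1.2-fold lower number from compound 3 to compound 4 (0.07 log units; within the scatter) and so shows that, at this position, the ring itself is not needed to keep the read-out where it stands. The step of an at least 3.0-fold lower number from compound 2 to compound 4 (0.48 log units; beyond the scatter) rests on a limit of the assay rather than a number for compound 2, while a 1.3-fold higher number from compound 1 to compound 4 (0.11 log units; within the scatter) places the simple butyl group level, within the scatter, with the much longer sulfonyl-bearing arm of compound 1. Compound 2 is the only one held at a limit: the limit of > 100000 nM in this assay, at which 1 of the 4 values shown sits.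

As far as these compounds go, whether any group here can bring the number down beyond the scatter stays open; an amine, a carboxylic acid or a longer chain would test this. A plain phenyl group would show whether the methoxy of compound 2 matters.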